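Swapping the Triazole Substituent of a Weak Growth Inhibitor

This account rests on a few compounds, and the source may have more. Where it says the series, first, only, none or still open, it means among the compounds named here.

Measured compounds:
compound 1 `O[C@H](COCCOC[C@@H](O)Cc1cn(Cc2ccc3ccccc3c2)nn1)Cc1ccc(-c2ccccc2)cc1` — 12100 nM
compound 2 `COC1=C(C)C(=O)C(CCCCCCCCCCn2cc(C[C@H](O)COCCOC[C@@H](O)Cc3ccc(-c4ccccc4)cc3)nn2)=C(C)C1=O` — 505 nM
compound 3 `CC1=C(CCCCCCCCCCn2cc(C[C@H](O)COCCOC[C@@H](O)Cc3ccc(-c4ccccc4)cc3)nn2)C(=O)c2ccccc2C1=O` — 390 nM

In a functional assay on SGC-7901 cells (Homo sapiens) for inhibition, read by MTT assay, with a stated time of 72 h (on this read-out higher numbers stand for weaker inhibition of growth and lower numbers for stronger inhibition of growth), compound 1 gives 12100 nM. That is the highest of the three numbers, and its gap to compound 2 and to compound 3 lies beyond the scatter, so compound 1 is the weakest growth inhibitor of the measured set. Compounds 2 and 3 each carry a long chain ending in a quinone on the triazole nitrogen, where compound 1 carries (naphthalen-2-yl)methyl.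

Compound 4 `O[C@H](COCCOC[C@@H](O)Cc1cn(-c2cccs2)nn1)Cc1ccc(-c2ccccc2)cc1` has not yet been measured in this assay. It differs from compound 1 in one place: thiophen-2-yl in place of (naphthalen-2-yl)methyl on an aromatic nitrogen. Going by the values given here, no measured pair shows this change, so its effect can only be guessed. The two potent compounds owe their numbers to a very different kind of substituent, and a small thiophen-2-yl is expected to move the number little, if anything towards weaker inhibition. The expected step from compound 1 to compound 4 is a 1.7-fold higher number from compound 1 to compound 4 (0.22 log units; within the scatter). For compound 4 the estimate is 20000 nM, within 6000 nM to 60000 nM.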

Compound 4, concentration for 50% growth inhibition: 33400 nM
Compound 4: middle estimate off by 1.7-fold (0.22 log units), on the low side; measured number inside the range.
By their numbers in this assay, from the lowest: compounds 3 and 2 (each within the scatter of the next); then compound 1; then compound 4.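

Putting thiophen-2-yl in place of (naphthalen-2-yl)methyl on the aromatic nitrogen gives a 2.8-fold higher number from compound 1 to compound 4 (0.44 log units; beyond the scatter) in this assay, so even this modest step shows that growth inhibition responds to a change between two aromatic substituents at this position. The entering group has fewer heavy atoms than the leaving one and goes with weaker inhibition, but this single pair cannot separate the number of heavy atoms, the sulfur atom and the loss of the carbon link to the aromatic nitrogen. No measurement at hand accounts for the step.

On these data alone, it remains open whether a benzyl group at this position would give a number closer to compound 1 or compound 4. Also open, as far as these compounds go, is how a long alkyl chain without a terminal quinone would compare with compound 1.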